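Two Bromophenyl Isomers on a Shared Core

The source may report more compounds than this note shows. Statements on the series, on what has been measured and on what is new or still open speak of the compounds shown alone.

In a functional assay on K562 cells (Homo sapiens) for inhibition, read by MTT assay, with a stated time of 72 h, tested at 10 uM (a higher number here means more inhibition at the concentration tested (going by the name of the read-out), a lower number less inhibition), compound 1 `CCOC(=O)C1=C(Nc2ccccc2)S/C(=C\c2ccc[nH]2)C1=O` gives 16.2%.
In this assay, compound 2 `CCOC(=O)C1=C(Nc2ccc(Br)cc2)S/C(=C\c2ccc[nH]2)C1=O` gives 17%.

Among the compounds with values here, compound 2 holds the highest of the two numbers in this assay, yet its nearest neighbour, compound 1, sits within the scatter of it: the single measured step, a number 0.8 percentage points higher from compound 1 to compound 2 (within the scatter), puts bromo in place of hydrogen on an aromatic carbon and changes the read-out by nothing beyond the scatter. Compound 3 `CCOC(=O)C1=C(Nc2ccccc2Br)S/C(=C\c2ccc[nH]2)C1=O` differs from compound 2 in one place: 2-bromophenyl in place of 4-bromophenyl on an amine nitrogen. Within the data shown here, no measured step exchanges a 4-bromophenyl for a 2-bromophenyl, so the only guidance is indirect, the step of a number 0.8 percentage points higher from compound 1 to compound 2 (within the scatter), which shows that bringing in the bromine at all left the read-out flat. The expected step in this assay is no change at the digits printed from compound 2 to compound 3 (within the scatter), none beyond the scatter. Compound 3 is therefore estimated at 17%, ranging from 5% to 30%.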

Compound 3, a percentage reported as inhibition, at one concentration (the size of the read-out at that concentration, not a potency): 20.5%
Compound 3: the middle estimate sits 3.5 percentage points below what was measured, and the stated range covers the measured number.
By their numbers in this assay, from the lowest: compounds 1, 2 and 3 (each within the scatter of the next).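

With 2-bromophenyl in place of 4-bromophenyl on the amine nitrogen, this assay gives a number 3.5 percentage points higher from compound 2 to compound 3 (within the scatter) and so does not tell the two bromophenyl isomers apart at this position. The earlier step tested only the 4-bromophenyl group, whereas the bromo in place of hydrogen on an aromatic carbon, now in the 2-bromophenyl form, gives a number 4.3 percentage points higher from compound 1 to compound 3 (within the scatter) and likewise stays inside the scatter, so neither bromophenyl group shown can be separated from the plain phenyl group of compound 1. Nothing available bears on why these three numbers lie so close together.

As far as these compounds go, whether any group on this phenyl ring can move the read-out beyond the scatter remains open, for instance a carboxylic acid or an amine in place of the bromine. The three compounds also leave open how far the read-out depends on the rest of the shared core, which is the same in all of them.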